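Swapping Selenium for Sulfur on a Side Chain

A few compounds are considered here, and "the series" means these few. Any claim that something is new, unique, unknown or untested is made for them only; others in the source may bear on it.

Measured compounds:
compound 1 `COc1ccc(N(CC(=O)NCCCSc2ccccc2)C(=O)CCSC2=C(C)C(=O)c3ccccc3C2=O)cc1`: 16000 nM
compound 2 `COc1ccc(N(CC(=O)NCCC[Se]c2ccccc2)C(=O)CCSC2=C(C)C(=O)c3ccccc3C2=O)cc1`: 8000 nM
compound 3 `COc1ccc(N(CC(=O)NCCC[Se]c2ccccc2)C(=O)C#Cc2ccccc2)cc1`: >= 100000 nM, a limit of the assay, not a number

In a functional assay on MCF7 cells (Homo sapiens) for cytotoxicity, read by MTT assay, with a stated time of 24 h (a higher number here means a weaker inhibitor, a lower number a stronger inhibitor), compound 2 gives 8000 nM and compound 1 gives 16000 nM. The two share one core and differ only by a group of 7 heavy atoms (6 carbon, 1 sulfur; one six-membered aromatic ring of carbon only) in place of a group of 7 heavy atoms (6 carbon, 1 selenium; one six-membered aromatic ring of carbon only), on a saturated chain carbon, three bonds along the chain from an amide-type nitrogen. That change produced a 2.0-fold higher number from compound 2 to compound 1 (0.30 log units; within the scatter), so the two values are not told apart here.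

Compound 3 rests on a different core; the difference between the two cores is not broken down here. In this assay compound 3 reaches only (the limit of >= 100000 nM in this assay, at which 1 of the 3 values shown sits), so no number is known for it.

Compound 4 `COc1ccc(N(CC(=O)NCCCSc2ccccc2)C(=O)C#Cc2ccccc2)cc1` has not been measured. It differs from compound 3 by a group of 7 heavy atoms (6 carbon, 1 sulfur; one six-membered aromatic ring of carbon only) in place of a group of 7 heavy atoms (6 carbon, 1 selenium; one six-membered aromatic ring of carbon only), on a saturated chain carbon, three bonds along the chain from an amide-type nitrogen, the same change made at the same place as between compound 2 and compound 1. The step from compound 3 to compound 4 is therefore expected to be small, a step that the limit leaves unreadable from compound 3 to compound 4, because the earlier one was a 2.0-fold higher number from compound 2 to compound 1 (0.30 log units; within the scatter). Compound 4 is expected to give about 150000 nM, most probably again only as a limit, between 50000 nM and 500000 nM.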

Compound 4, half-maximal inhibitory concentration: >= 100000 nM
Compound 4 was reported as a limit; the forecaster's own chance of this, stated with the estimate: 85%; the middle value does not contradict the limit.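

Compound 3 and compound 4 both stop at a limit of this assay rather than a number, so the step from selenium to sulfur between them cannot be read: the limit of >= 100000 nM in this assay, at which 2 of the 4 values shown sit.

The compounds shown leave open what actual numbers compound 3 and compound 4 would give, and whether this swap makes any difference on their core.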